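This account rests on a few compounds, and the source may have more. Where it says the series, first, only, none or still open, it means among the compounds named here.

Working notes on the series. In a functional assay on MCF7 cells (Homo sapiens) for cytotoxicity, read by MTT assay, with a stated time of 48 h (on this read-out lower numbers stand for stronger inhibition and higher numbers for weaker inhibition), compound 1 (`COc1cc(/C=C/C(=O)/C=C/c2nc3ccccc3n2C)ccc1O`) reads 3700 nM and compound 2 (`COc1ccc2c(c1)nc(/C=C/C(=O)/C=C/c1ccc(O)c(OC)c1)n2C`) reads 3900 nM and so stands within the scatter of compound 1. Next is compound 3 (`COc1cc(/C=C/C(=O)/C=C/c2nc3cc(Cl)ccc3n2C)ccc1O`), reached from compound 2 by chloro in place of methoxy on an aromatic carbon. Among the compounds with values here, the only measured step at this aromatic carbon is a 1.1-fold higher number from compound 1 to compound 2 (0.02 log units; within the scatter) for methoxy in place of hydrogen, and it lies within the scatter. Within the data shown here, no measured compound carries chloro, so the evidence is thin, and no step beyond the scatter is expected in this assay for this change. The expected size of the step is a 1.1-fold lower number from compound 2 to compound 3 (0.02 log units; within the scatter) by this estimate. Compound 3 is estimated at 3700 nM with a range from 1600 nM to 8500 nM as the expected span.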

Compound 3, half-maximal inhibitory concentration: 4400 nM
Estimate against measurement, compound 3: 1.2-fold (0.08 log units) below; the measured number falls inside the stated range.
By their numbers in this assay, from the lowest: compounds 1, 2 and 3 (each within the scatter of the next).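

At this aromatic carbon, chloro now stands alongside methoxy and hydrogen: in this assay, chloro in place of methoxy gives a 1.1-fold higher number from compound 2 to compound 3 (0.05 log units; within the scatter), and chloro in place of hydrogen gives a 1.2-fold higher number from compound 1 to compound 3 (0.08 log units; within the scatter). Both steps lie within the scatter, so with a third group at this position, the read-out still does not separate hydrogen, methoxy and chloro across compound 1, compound 2 and compound 3. No measurement at hand bears on the reason for this result.

As far as these compounds go, whether an amine, a carboxylic acid or a longer chain at this aromatic carbon would give a step beyond the scatter remains open. Also open, from the compounds shown here alone, is whether chloro in place of hydrogen would stay within the scatter on the other aromatic carbons of this ring.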